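A fluorine moved on the aryl group of compound 2

This account rests on a few compounds, and the source may have more. Where it says the series, first, only, none or still open, it means among the compounds named here.

In an ADME assay on HEK-293T cells (Homo sapiens) for cytotoxicity, read by MTT assay, with a stated time of 72 h (a lower number here means a stronger inhibitor, a higher number a weaker inhibitor), compound 1 `CC1(C)[C@@H]2CC[C@@]1([C@H](O)CN1CCN(c3ccc(F)cc3)CC1)C(=O)C2` gives 65100 nM and compound 2 `CC1(C)[C@@H]2CC[C@@]1([C@@H](O)CN1CCN(c3ccc(F)cc3)CC1)C(=O)C2` gives 82200 nM on the same scale. Compound 2 stands level with compound 1: the gap is a 1.3-fold higher number from compound 1 to compound 2 (0.10 log units; within the scatter) and it goes with the fact that compounds 1 and 2 differ only in the configuration as drawn alone. Compound 3 `CC1(C)[C@@H]2CC[C@@]1([C@@H](O)CN1CCN(c3ccccc3F)CC1)C(=O)C2` differs from compound 2 as follows: 2-fluorophenyl in place of 4-fluorophenyl on an amine nitrogen in a ring with 2-fluorophenyl in place of 4-fluorophenyl on an amine nitrogen in a ring. Within the data shown here, no measured step touches this group, so no shift beyond the scatter is expected in this assay on present evidence. The estimated move is a 1.1-fold lower number from compound 2 to compound 3 (0.04 log units; within the scatter) in size. Compound 3 is expected at 75000 nM within a range from 35000 nM to 160000 nM for now.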

Compound 3, half-maximal inhibitory concentration: 129000 nM
For compound 3 the middle estimate is 1.7-fold (0.24 log units) below the measured one, within the range that was stated.
By their numbers in this assay, from the lowest: compounds 1, 2 and 3 (each within the scatter of the next).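

On the amine nitrogen in a ring, 2-fluorophenyl in place of 4-fluorophenyl gives a 1.6-fold higher number from compound 2 to compound 3 (0.20 log units; within the scatter) in this assay, so this shift of the fluorine leaves the number within the scatter. This is the first reading of the aryl group at this position, and it shows the cytotoxicity number tolerating this change among the compounds shown. Nothing available bears on a cause for this step. The compounds shown leave open whether a chlorine or a methoxy group on the phenyl, or a pyridine ring in its place, would also stay within the scatter in this assay.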